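The source may report more compounds than this note shows. Statements on the series, on what has been measured and on what is new or still open speak of the compounds shown alone.

For the measured compounds named here, the three compounds measured so far share one core and differ only in the chain and the amide it carries. Compound 1 `COc1ccc(CCCNC(C)=O)cc1` gives 14000 nM in an assay for binding affinity to melatonin receptor (Gallus gallus); on this read-out higher numbers stand for weaker inhibition and lower numbers for stronger inhibition. Compound 2 `CCC(=O)NCCCc1ccc(OC)cc1` gives 2900 nM in this assay, and compound 3 `COc1ccc(CCCCNC(C)=O)cc1` gives 7300 nM. Compound 3 therefore stands second highest of the three numbers: the step of a 1.9-fold lower number from compound 1 to compound 3 (0.28 log units; within the scatter) lies within the scatter, whereas the step of a 2.5-fold higher number from compound 2 to compound 3 (0.40 log units; beyond the scatter) lies beyond it.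

Compound 4 `CCCC(=O)NCCCCc1ccc(OC)cc1` differs from compound 3 by ethyl in place of hydrogen on a saturated chain carbon bound to a carbonyl carbon. The step that bears most directly on this change is a 4.8-fold lower number from compound 1 to compound 2 (0.68 log units; beyond the scatter), where the same place received methyl in place of hydrogen. The reverse direction is touched by a 2.5-fold higher number from compound 2 to compound 3 (0.40 log units; beyond the scatter), which exchanges propanoylamino for acetamidomethyl and is a modest rise. Going by the values given here, no measured pair shows an ethyl at this place, so the expectation rests on the one modest step from compound 1 to compound 2 rather than on a direct precedent.

On that basis compound 4 is expected to show a lower number than compound 3, with the estimated step of a 4.9-fold lower number from compound 3 to compound 4 (0.69 log units; beyond the scatter) because of the earlier 4.8-fold lower number from compound 1 to compound 2 (0.68 log units; beyond the scatter). The estimate for compound 4 in this assay is 1500 nM, in a range from 400 nM to 5000 nM.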

Compound 4, inhibition constant: 822 nM
Compound 4: the middle estimate sits 1.8-fold (0.26 log units) above what was measured; the range from low to high includes it.
By their numbers in this assay, from the lowest: compound 4; then compound 2; then compounds 3 and 1 (each within the scatter of the next).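

The step of an 8.9-fold lower number from compound 3 to compound 4 (0.95 log units; beyond the scatter) shows that this place, a saturated chain carbon bound to a carbonyl carbon, accepts ethyl as well as methyl, and that the number falls again with the larger group. For the compounds shown here, until now the only evidence at this place was a 4.8-fold lower number from compound 1 to compound 2 (0.68 log units; beyond the scatter) on the chain of compound 1, so the lowering is now seen on two different chains, with both steps beyond the scatter and running the same way, and the ethyl step is the larger in print, although these two steps differ in both the group added and the chain that carries it. Nothing given here says what lies behind this fall in the number.

The compounds shown leave open whether methyl alone on the chain of compound 3, or ethyl on the chain of compound 1, would give a comparable step, so the share of the group and the share of the chain cannot be separated. They also leave open how far this trend runs, for instance whether a longer chain such as pentyl, a branched isopropyl, a cyclopropyl ring or an amine at this place would lower the number further or raise it.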